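Nitrooxy in place of hydrogen on the chain carbon of compound 3

The source may report more compounds than this note shows. Statements on the series, on what has been measured and on what is new or still open speak of the compounds shown alone.

Compound 1, `O=c1c2ccccc2nc(CO[N+](=O)[O-])n1NS(=O)(=O)c1ccccc1`: 55%
Compound 2, `Cc1ccc(S(=O)(=O)Nn2c(CO[N+](=O)[O-])nc3ccccc3c2=O)cc1`: 71.6%
Compound 3, `CC(=O)Nc1ccc(S(=O)(=O)Nn2c(C)nc3ccccc3c2=O)cc1`: 95.7%

Three compounds sharing one core were tested in a functional assay on the whole organism (strain Sprague-Dawley) for inhibition, with Rattus norvegicus as the target, read by paw edema, with stated times of 30 min and 3 h, at a dose of 80 mg/kg by the oral route; a lower number here means less inhibition, a higher number more inhibition at the dose given (going by the name of the read-out). Compound 1 gives 55%, compound 2 gives 71.6%, and compound 3 gives 95.7%. Compound 3 stands highest of the three: its nearest neighbour is compound 2, whose number is lower by a margin beyond the scatter, and compound 1 lies further below. For the measured compounds named here, the one single-point step among the measured compounds is a number 16.6 percentage points higher from compound 1 to compound 2 (beyond the scatter), a methyl in place of hydrogen on an aromatic carbon. Going by the values given here, compound 2 and compound 3 differ in two places at once, so their values show only that compound 3 sits higher.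

Compound 4, `CC(=O)Nc1ccc(S(=O)(=O)Nn2c(CO[N+](=O)[O-])nc3ccccc3c2=O)cc1`, is the compound yet to be measured in this assay. It differs from compound 3 by nitrooxy in place of hydrogen on a saturated chain carbon bound to an aromatic carbon, or, cut one bond further out, methyl to (nitrooxy)methyl. Among the compounds with values here, no measured step involves this particular change, so there is no direct precedent; the one measured step concerns an aromatic carbon, not the chain. The number for compound 3 is already the highest of the three, which leaves little room upward. The expectation is therefore a step of a number 10.7 percentage points lower from compound 3 to compound 4 (beyond the scatter), within or near the scatter, most likely a slight drop. Compound 4 is estimated at 85%, within a range from 65% to 98%.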

Compound 4, a percentage reported as inhibition, in the whole organism at one dose (the size of the read-out at that dose, not a potency): > 100%
Compound 4 was reported as a limit; the forecaster's own chance of this, stated with the estimate: 0%; middle value at least 15 percentage points from the limit.
By their numbers in this assay, from the lowest: compound 1; then compound 2; then compound 3. At a limit, above all of these: compound 4.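

In this assay compound 4 is reported as > 100%, which is a limit and not a number: the limit of > 100% in this assay, at which 1 of the 4 values shown sits. Nitrooxy in place of hydrogen on a saturated chain carbon bound to an aromatic carbon gives a number at least 4.3 percentage points higher from compound 3 to compound 4 (that floor lies within the scatter), so this change, which no earlier step covered, shows no loss on a compound already high in the series, though the floor is too small to claim a gain. For the compounds shown here, with the nitrooxy chain held constant, the group on the aromatic carbon proves to matter more than the single methyl step suggested, since acetamido gives a number at least 28.4 percentage points higher from compound 2 to compound 4 (beyond the scatter) and a number at least 45 percentage points higher from compound 1 to compound 4 (beyond the scatter).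

Going by these compounds alone, the nitrooxy step is seen only with acetamido on the aromatic carbon, so whether it would hold with hydrogen or methyl there stays open, as does how far compound 4 really lies past its limit. Also open, on these data alone, is how an amine or a carboxylic acid would read in place of acetamido, and how a longer chain would read in place of the (nitrooxy)methyl.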